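The compounds below may be only part of what the source reports. "The series", "measured", "known", "first", "only" and "open" are said of these compounds alone.

Compound 1 `COc1ccc(CC[C@@H](OC(=O)[C@@H]2CCCCN2C(=O)c2cccc3ccccc23)c2cccc(OCC(=O)O)c2)cc1OC`: in a physicochemical assay for solubility (on this read-out higher numbers stand for higher solubility and lower numbers for lower solubility), compound 1 gives > 10000 nM, a limit of the assay.
Compound 2 `COc1ccc(CC[C@@H](OC(=O)[C@@H]2CCCCN2C(=O)c2nccc3ccccc23)c2cccc(OCC(=O)O)c2)cc1OC`: in this assay compound 2 gives > 10000 nM, likewise a limit.
Compound 3 `COc1ccc(CC[C@@H](OC(=O)[C@@H]2CCCCN2C(=O)c2cccc3c2CCCC3)c2cccc(OCC(=O)O)c2)cc1OC`: in this assay compound 3 gives > 10000 nM, also a limit.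

Compound 3 therefore stands at the limit, as do the two others. The steps a step that the two limits leave unreadable from compound 1 to compound 2, a step that the two limits leave unreadable from compound 1 to compound 3 and a step that the two limits leave unreadable from compound 2 to compound 3 carry no readable size because of the limit of > 10000 nM in this assay, at which 3 of the 3 values shown sit. Compound 4 `COc1ccc(CC[C@@H](OC(=O)[C@@H]2CCCCN2C(=O)[C@@H]2CCCc3ccccc32)c2cccc(OCC(=O)O)c2)cc1OC` differs from compound 3 in 1,2,3,4-tetrahydronaphthalen-1-yl in place of 1,2,3,4-tetrahydronaphthalen-5-yl on a carbonyl carbon. The three measured steps bear on this change only in that each swaps the group on the same carbonyl carbon, and none of them moved the read-out off the limit. No step beyond the scatter is expected here. Compound 4 is expected at 15000 nM, with a range from 8000 nM to 40000 nM. The step that the limit leaves unreadable from compound 3 to compound 4 is expected to remain unreadable at the limit.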

Compound 4, solubility: > 10000 nM
Compound 4: a limit, no number (the forecaster's own chance of this, stated with the estimate: 80%); the middle value is on the limit's open side.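

No step can be read between compound 4 and compound 1, compound 2 or compound 3, because all four stand at a limit: the limit of > 10000 nM in this assay, at which 4 of the 4 values shown sit.

The compounds shown leave open how the groups on the carbonyl carbon compare in this assay.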